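A few compounds are considered here, and "the series" means these few. Any claim that something is new, unique, unknown or untested is made for them only; others in the source may bear on it.

In an ADME assay on GES1 cells (Homo sapiens) for inhibition, read by MTT assay, with a stated time of 72 h (a lower number here means a stronger inhibitor, a higher number a weaker inhibitor), compound 1 `Cc1cc(Nc2cc(-c3ccccc3)[nH]n2)n2nc(SCC3CCCCC3)nc2n1` reaches only a limit of the assay, > 50000 nM. Going by the values given here, compound 2 `Cc1cc(Nc2cc(-c3ccccc3)[nH]n2)n2nc(SCc3csc4ccccc34)nc2n1` gives 29200 nM, the only actual number so far. Among the compounds with values here, the one measured step, an at least 1.7-fold lower number from compound 1 to compound 2 (0.23 log units; that floor lies within the scatter), has a floor that lies within the scatter, so it shows no firm gain. Compound 3 `CCCSc1nc2nc(C)cc(Nc3cc(-c4ccccc4)[nH]n3)n2n1` changes the same place again: ethyl in place of 1-benzothiophen-3-yl on a saturated chain carbon bound to a sulfur. Compound 1, which also lacks 1-benzothiophen-3-yl, stands at the limit of > 50000 nM, so a modest move towards a higher number is expected, and compound 3 may itself reach that limit. The expected change is a 1.5-fold higher number from compound 2 to compound 3 (0.19 log units; within the scatter). For compound 3, the estimated value is 45000 nM, with an expected range of 20000 nM to 100000 nM.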

Compound 3, half-maximal inhibitory concentration: > 50000 nM
Compound 3 ended at the assay's limit; the forecaster's own chance of this, stated with the estimate: 50%; at least 1.1-fold (0.04 log units) between middle value and limit.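

With ethyl on the saturated chain carbon bound to a sulfur, this assay shows an at least 1.7-fold higher number from compound 2 to compound 3 (0.23 log units; that floor lies within the scatter), so this change, like the first one, shows no firm shift. Both cyclohexyl and ethyl now end at a limit of the assay, and only 1-benzothiophen-3-yl gives an actual number, although neither step to compound 2 is firmly beyond the scatter. The step between compound 1 and compound 3 cannot be read, so cyclohexyl and ethyl cannot be ordered, and the position offers little to compare: the limit of > 50000 nM in this assay, at which 2 of the 3 values shown sit.

The compounds shown leave open how far compound 1 and compound 3 lie past that limit. They also leave open whether phenyl, an amine or a carboxylic acid in this place would give a number.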